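The compounds below may be only part of what the source reports. "The series", "measured", "known", "first", "only" and "open" are said of these compounds alone.

Measured in an ADME assay on the whole organism (strain Sprague-Dawley) for pharmacokinetics, with Rattus norvegicus as the target, using cassette dosing, at a dose of 1 mg/kg by the oral route; a higher number here means that a larger share of the oral dose reaches the circulation, a lower number that a smaller share of the oral dose reaches the circulation:
- compound 1 `O=c1ccc(-c2cc(C[C@]3(O)CC[C@@H](Cc4ccccc4)CC3)no2)c[nH]1`: 53.1%
- compound 2 `O=c1ccc(-c2cc(C[C@]3(O)CC[C@@H](Cc4ccc(Cl)cc4)CC3)no2)c[nH]1`: 37.2%

Compound 2 has the lower of the two numbers, and its gap to compound 1 lies beyond the scatter. Compound 3 `O=c1ccc(-c2cc(C[C@]3(O)CC[C@H](Cc4ccc(Cl)cc4)CC3)no2)c[nH]1` has the same atoms and bonds as compound 2: the two compounds have the same atoms and bonds and differ only in configuration as drawn: 2 of 2 stereo elements differ (all stereocentres are inverted: mirror images); a stereocentre at a saturated ring carbon is drawn s in compound 2 and r in compound 3; a stereocentre at a saturated ring carbon is drawn s in compound 2 and r in compound 3. Among the measured compounds shown here, the only measured step, a number 15.9 percentage points lower from compound 1 to compound 2 (beyond the scatter), is chloro in place of hydrogen on an aromatic carbon. For the measured compounds named here, it changes no configuration, so it gives only a rough scale for this series, and no measured step tests the inversion. No direction can be supported, so the expected step is none beyond the scatter: a number 1.2 percentage points lower from compound 2 to compound 3 (within the scatter). Compound 3 is estimated at 36%, within a range of 20% to 54%.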

Compound 3, oral bioavailability: 38.7%
Compound 3: middle estimate off by 2.7 percentage points, on the low side; measured number inside the range.
By their numbers in this assay, from the lowest: compounds 2 and 3 (each within the scatter of the next); then compound 1.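

In this assay, inverting both stereocentres at the saturated ring carbons, with the chloro group kept, gives a number 1.5 percentage points higher from compound 2 to compound 3 (within the scatter). Among the compounds shown here, this is the first read on configuration, and the comparison isolates it: the fact that compounds 2 and 3 differ only in the configuration as drawn. For the compounds shown here, with chloro present, the configuration as drawn does not separate these mirror images, so the chloro step remains the only change beyond the scatter.

Open, on these data alone, is whether the inversion has equally little effect without chloro, as in compound 1. Also open, as far as these compounds go, is how a methoxy group or a nitrile on that aromatic carbon would compare with chloro.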